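Compound 4: swapping a double bond for a triple bond

The compounds below may be only part of what the source reports. "The series", "measured", "known", "first", "only" and "open" are said of these compounds alone.

- compound 1 `Cn1cncc1C(OCc1ccc(C#N)cc1C#Cc1ccccn1)c1ccc(C#N)cc1` gives > 0.1 nM (a limit, not a number)
- compound 2 `Cn1cncc1C(OCc1ccc(C#N)cc1C#CC1(O)CCCCC1)c1ccc(C#N)cc1` gives 1.93 nM
- compound 3 `Cn1cncc1C(OCc1ccc(C#N)cc1/C=C/c1ccc([N+](=O)[O-])cc1)c1ccc(C#N)cc1` gives 2.24 nM

All three were tested in a functional assay on NIH3T3 cells (Mus musculus); a higher number here means that more compound is needed for the effect, a lower number that less compound is needed. Among the compounds with values here, compound 3 stands level with compound 2, the only other compound with a true number. Compound 4 `Cn1cncc1C(OCc1ccc(C#N)cc1C#Cc1ccc([N+](=O)[O-])cc1)c1ccc(C#N)cc1` differs from compound 3 by one change: 2-(4-nitrophenyl)ethynyl in place of 2-(4-nitrophenyl)ethenyl on an aromatic carbon. Within the data shown here, the one readable step that bears on this is a 1.2-fold higher number from compound 2 to compound 3 (0.06 log units; within the scatter), and it swapped the whole side chain. Compound 1 offers only a step that the limit leaves unreadable from compound 1 to compound 3. On the evidence of compound 2 and compound 3 at a 1.2-fold higher number from compound 2 to compound 3 (0.06 log units; within the scatter), no shift beyond the scatter is expected in this assay, and the expected change is a 1.1-fold lower number from compound 3 to compound 4 (0.05 log units; within the scatter). Compound 4 is estimated at 2 nM, with an expected range of 0.6 nM to 7 nM.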

Compound 4, half-maximal effective concentration: 36 nM
Compound 4: the middle estimate sits 18-fold (1.26 log units) below what was measured; the whole stated range lies below it.
By their numbers in this assay, from the lowest: compounds 2 and 3 (each within the scatter of the next); then compound 4.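

In this assay, this place on the aromatic carbon proves sensitive to the linking bond: with the 4-nitrophenyl kept, the triple bond in place of the double bond gives a 16-fold higher number from compound 3 to compound 4 (1.21 log units; beyond the scatter). The triple bond alone does not set the number, since keeping it and exchanging 1-hydroxycyclohexyl for 4-nitrophenyl gives a 19-fold higher number from compound 2 to compound 4 (1.27 log units; beyond the scatter). The step from compound 1 cannot be read: the limit of > 0.1 nM in this assay, at which 1 of the 4 values shown sits.

Still open, on these data alone, is whether a 2-(1-hydroxycyclohexyl)ethenyl group would match compound 2. Also open, as far as these compounds go, is how an amine in place of the nitro group would behave on either link.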